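The source may report more compounds than this note shows. Statements on the series, on what has been measured and on what is new or still open speak of the compounds shown alone.

Of the compounds shown here, three sharing one core have been tested in a functional assay on Huh-7 cells (Homo sapiens) for inhibition, read by MTT assay, with a stated time of 48 h; a higher number here means a weaker inhibitor, a lower number a stronger inhibitor. Compound 1 `COc1ccc2c(=O)c(/C=C/C(=O)Nc3ccccc3)coc2c1` gives 9050 nM. Compound 2 `COc1ccc(CNC(=O)/C=C/c2coc3cc(OC)ccc3c2=O)cc1` gives 7570 nM, and the step of a 1.2-fold lower number from compound 1 to compound 2 (0.08 log units; within the scatter). Compound 3 `COc1ccc2c(=O)c(/C=C/C(=O)Nc3ccccc3C)coc2c1` gives 26900 nM, the highest of the three numbers: both the step of a 3.0-fold higher number from compound 1 to compound 3 (0.47 log units; beyond the scatter) and the step of a 3.6-fold higher number from compound 2 to compound 3 (0.55 log units; beyond the scatter) lie beyond the scatter, so compound 3 is the weakest inhibitor among the measured compounds.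

Compound 4 `COc1ccc2c(=O)c(/C=C/C(=O)Nc3ccc(Cl)cc3)coc2c1` is not yet measured. The change from compound 3 is 4-chlorophenyl in place of 2-methylphenyl on an amide-type nitrogen. Within the data shown here, two measured steps bear on it. The methyl that entered in the step of a 3.0-fold higher number from compound 1 to compound 3 (0.47 log units; beyond the scatter) is removed again in compound 4, which by itself points back toward the number of compound 1. The step of a 3.6-fold higher number from compound 2 to compound 3 (0.55 log units; beyond the scatter) shows the same 2-methylphenyl group leaving, again with a fall in the number. Among the measured compounds shown here, the chlorine has no precedent here: no measured compound carries a halogen, so its own contribution is unknown. The expectation is therefore a step of a 3.0-fold lower number from compound 3 to compound 4 (0.48 log units; beyond the scatter), a fall of modest size. Compound 4 is estimated at 9000 nM, with a range from 3000 nM to 27000 nM.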

Compound 4, half-maximal inhibitory concentration: 37100 nM
Compound 4: the middle estimate sits 4.1-fold (0.62 log units) below what was measured; measured number above the stated range.
By their numbers in this assay, from the lowest: compounds 2 and 1 (each within the scatter of the next); then compounds 3 and 4 (each within the scatter of the next).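

The new result shows that this amide-nitrogen position tolerates a second kind of substituted phenyl no better than the first: adding a chlorine to the plain phenyl gives a 4.1-fold higher number from compound 1 to compound 4 (0.61 log units; beyond the scatter) in this assay, so the plain phenyl of compound 1 holds the lower number against both substituted phenyl groups shown. Exchanging 2-methylphenyl for 4-chlorophenyl gives a 1.4-fold higher number from compound 3 to compound 4 (0.14 log units; within the scatter), so this assay does not tell those two groups apart, and 4-chlorophenyl in place of 4-methoxybenzyl gives a 4.9-fold higher number from compound 2 to compound 4 (0.69 log units; beyond the scatter), which places 4-chlorophenyl on the weaker side of the series alongside 2-methylphenyl. No measurement available here explains why either substituent goes with a higher number.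

Each substituent appears in only one form, as 2-methylphenyl or as 4-chlorophenyl, so the compounds shown cannot separate the effect of the group itself from that of where it sits on the ring. They also leave open how a fluorine, a hydroxyl, an amine or a carboxylic acid on that phenyl ring would read, and whether a plain benzyl group would match 4-methoxybenzyl.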